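Pyrimidin-4-yl amide in a weak antiproliferative series

A few compounds are considered here, and "the series" means these few. Any claim that something is new, unique, unknown or untested is made for them only; others in the source may bear on it.

Three analogues share a core and differ only in the aromatic ring on the amide carbonyl. In a functional assay on NCI-H1975 cells (Homo sapiens) for antiproliferative activity, read by MTT assay, with a stated time of 72 h (a lower number here means a stronger inhibitor, a higher number a weaker inhibitor), compound 1 `COc1cc(N(C)C)c(NC(=O)c2ccncc2)cc1Nc1nccc(-c2cn(C)c3ccccc23)n1` gives 1470 nM and compound 2 `COc1ccc(C(=O)Nc2cc(Nc3nccc(-c4cn(C)c5ccccc45)n3)c(OC)cc2N(C)C)nc1` gives 2130 nM, a pair separated by a 1.4-fold higher number from compound 1 to compound 2 (0.16 log units; within the scatter). Compound 3 `COc1cc(N(C)C)c(NC(=O)c2ccccn2)cc1Nc1nccc(-c2cn(C)c3ccccc23)n1` gives 10400 nM in this assay, the highest number of the three; the steps of a 7.1-fold higher number from compound 1 to compound 3 (0.85 log units; beyond the scatter) and a 4.9-fold higher number from compound 2 to compound 3 (0.69 log units; beyond the scatter) both lie beyond the scatter, so compound 3 is the weakest measured inhibitor in this assay.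

Compound 4 `COc1cc(N(C)C)c(NC(=O)c2ccncn2)cc1Nc1nccc(-c2cn(C)c3ccccc23)n1` carries the change (pyrimidin-4-yl in place of pyridin-2-yl on a carbonyl carbon). The step that bears most directly on it is a 7.1-fold higher number from compound 1 to compound 3 (0.85 log units; beyond the scatter), which shows that the ring on the carbonyl carbon can shift this assay by a modest amount; a 4.9-fold higher number from compound 2 to compound 3 (0.69 log units; beyond the scatter) shows the same scale. Among the compounds with values here, no measured pair contains a pyrimidin-4-yl ring, so the direction is uncertain, but compound 3 sits at the weak end and compound 4 is expected to move back toward the other analogues by a 2.1-fold lower number from compound 3 to compound 4 (0.32 log units; beyond the scatter). For compound 4 the estimate in this assay is 5000 nM, with a range from 1500 nM to 16000 nM.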

Compound 4, half-maximal inhibitory concentration: 1250 nM
Estimate against measurement, compound 4: 4.0-fold (0.60 log units) above, and the stated range ends above it.
By their numbers in this assay, from the lowest: compounds 4, 1 and 2 (each within the scatter of the next); then compound 3.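

Setting pyrimidin-4-yl in place of pyridin-2-yl on the carbonyl carbon gives an 8.3-fold lower number from compound 3 to compound 4 (0.92 log units; beyond the scatter) in this assay, so a ring with a second ring nitrogen at this position does not share the weakness of compound 3. The steps of a 1.7-fold lower number from compound 2 to compound 4 (0.23 log units; within the scatter) and a 1.2-fold lower number from compound 1 to compound 4 (0.07 log units; within the scatter) leave pyrimidin-4-yl, 5-methoxypyridin-2-yl and pyridin-4-yl without any order in this assay, which makes the unsubstituted pyridin-2-yl ring the only one of the four that stands apart. Nothing given here explains why that ring differs from the other three.

The compounds shown leave open whether this position tolerates anything other than a six-membered aromatic ring, such as a five-membered thiazole, a saturated piperidine or a morpholine. They also leave open whether a methoxy group on pyrimidin-4-yl would shift the value in this assay at all.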